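A few compounds are considered here, and "the series" means these few. Any claim that something is new, unique, unknown or untested is made for them only; others in the source may bear on it.

Among the measured compounds shown here, only two compounds sharing one core have been tested so far in a functional assay on PC-3 cells (Homo sapiens) for inhibition, read by sulforhodamine B assay; a lower number here means a stronger inhibitor of growth, a higher number a weaker inhibitor of growth. Compound 1 `COc1ccc(-c2ccc(-c3ccc(-c4nc5ccccc5[nH]4)cc3)cc2)cc1OC` gives 47100 nM, and compound 2 `COc1cc(-c2ccc(-c3ccc(-c4nc5ccccc5[nH]4)cc3)cc2)cc(OC)c1OC` gives 9720 nM, the lower of the two numbers and so the stronger inhibitor of growth. The next compound to be tested is compound 3 `COc1cc(-c2ccc(-c3ccc(-c4nc5c(O)cccc5[nH]4)cc3)cc2)cc(OC)c1OC`, which alters compound 2 in one place: hydroxy in place of hydrogen on an aromatic carbon. In words, this is hydroxy in place of hydrogen on an aromatic carbon, turning 1H-benzimidazol-2-yl into 4-hydroxy-1H-benzimidazol-2-yl. For the measured compounds named here, the only measured step, a 4.8-fold lower number from compound 1 to compound 2 (0.69 log units; beyond the scatter), came from adding methoxy at a different place in the molecule. It is modest but beyond the scatter. Going by the values given here, no measured compound carries a hydroxy, so this step offers only a rough idea of how far one small added group can move the number, and it says little about direction. The estimated step is a 1.9-fold lower number from compound 2 to compound 3 (0.29 log units; within the scatter), a small move toward a lower number, held with little confidence. For compound 3 the estimated value is 5000 nM, with an expected range from 1300 nM to 20000 nM.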

Compound 3, concentration for 50% growth inhibition: 170 nM
Estimate against measurement, compound 3: 29-fold (1.47 log units) above; measured number below the stated range.
By their numbers in this assay, from the lowest: compound 3; then compound 2; then compound 1.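

Adding a hydroxy to the six-membered aromatic ring of carbon only, which is part of the fused system, gives a 57-fold lower number from compound 2 to compound 3 (1.76 log units; beyond the scatter) in this assay. This is a much larger move than the earlier methoxy change elsewhere in the molecule, a 4.8-fold lower number from compound 1 to compound 2 (0.69 log units; beyond the scatter), so among these three compounds, the ring that turns 1H-benzimidazol-2-yl into 4-hydroxy-1H-benzimidazol-2-yl is where a single added heavy atom shifts growth inhibition most. Nothing measured here explains why this one oxygen-bearing group has so large an effect.

The compounds shown cannot tell whether the gain needs a hydroxy specifically, since a methoxy, an amine or a fluorine at the same place would separate that group from other small substituents. They also leave open whether a hydroxy on another carbon of that ring would do the same, and whether the same change would give a similar step on the core of compound 1, which carries one methoxy fewer.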